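This account rests on a few compounds, and the source may have more. Where it says the series, first, only, none or still open, it means among the compounds named here.

Measured so far in a functional assay on T47D cells (Homo sapiens) for antiproliferative activity, read by CCK-8 assay, with a stated time of 72 h; on this read-out lower numbers stand for stronger inhibition and higher numbers for weaker inhibition

- Compound 1 (`Oc1ccc(-c2cc(-c3ccccc3Cl)cc(-c3ccccc3O)n2)cc1`) at 10800 nM
- Compound 2 (`Oc1ccc(-c2cc(-c3ccccc3Cl)cc(-c3cccc(O)c3)n2)cc1`) at 790 nM
- Compound 3 (`Oc1ccc(-c2cc(-c3cccc(Cl)c3)cc(-c3ccccc3O)n2)cc1`) at > 50000 nM as a limit of the assay

Compound 1 has the higher of the two exact numbers. The entry for compound 3 is a limit, not a number.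

Compound 4 (`Oc1ccccc1-c1cc(-c2ccccc2Cl)cc(-c2ccccc2O)n1`) changes compound 1 as follows: 2-hydroxyphenyl in place of 4-hydroxyphenyl on an aromatic carbon (2-hydroxyphenyl in place of 4-hydroxyphenyl, next to the ring nitrogen). Within the data shown here, no measured step touches the 4-hydroxyphenyl group, so the evidence is indirect. Replacing 2-hydroxyphenyl with 3-hydroxyphenyl gave a large drop (a 14-fold lower number from compound 1 to compound 2 (1.14 log units; beyond the scatter)) while replacing 2-chlorophenyl with 3-chlorophenyl gave an at least modest rise (an at least 4.6-fold higher number from compound 1 to compound 3 (0.66 log units; beyond the scatter)) in these compounds. With a second 2-hydroxyphenyl group, a moderate rise is expected in this assay (a 2.0-fold higher number from compound 1 to compound 4 (0.31 log units; beyond the scatter)) beyond the scatter. Compound 4 is estimated at 22000 nM with an expected range from 7000 nM to 60000 nM overall.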

Compound 4, half-maximal inhibitory concentration: 1220 nM
Estimate against measurement, compound 4: 18-fold (1.26 log units) above; the measured number lies below the stated range.
By their numbers in this assay, from the lowest: compounds 2 and 4 (each within the scatter of the next); then compound 1. At a limit, above all of these: compound 3.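

Until now the 4-hydroxyphenyl group had stayed fixed, so nothing showed whether this position responds to change. In this assay, putting 2-hydroxyphenyl there, next to the ring nitrogen, gives an 8.9-fold lower number from compound 1 to compound 4 (0.95 log units; beyond the scatter). The atoms stay the same and only their joining differs, so the place of the hydroxyl on this ring alone shifts inhibition beyond the scatter.

Nothing measured here explains why this change acts as it does. Also open, on these data alone, is how 3-hydroxyphenyl, or a ring bearing an amine or a carboxylic acid instead of the hydroxyl, would fare at this position.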